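Three Methyl Groups Added to a Sulfonyl Phenyl Ring

The compounds below may be only part of what the source reports. "The series", "measured", "known", "first", "only" and "open" are said of these compounds alone.

Compound 1 `CC[C@H](C)[C@H](NC(=O)c1cccc(Cn2ccnc2)c1)C(=O)NNS(=O)(=O)c1ccccc1` gives 6% in an assay on HEK293 cells for displacement of a labelled ligand from Type-2 angiotensin II receptor (Homo sapiens), tested at 1 uM; a lower number here means a weaker effect, a higher number a stronger effect of the compound at the concentration tested.
Compound 2 `CC[C@H](C)[C@H](NC(=O)c1cccc(Cn2ccnc2)c1)C(=O)NS(=O)(=O)c1ccccc1` gives 5% in this assay.
Compound 3 `CCCCS(=O)(=O)NNC(=O)[C@@H](NC(=O)c1cccc(Cn2ccnc2)c1)[C@@H](C)CC` gives "not determined" (no result reported) in this assay.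

Compound 1 holds the higher of the two numbers, yet the step of a number 1 percentage points lower from compound 1 to compound 2 (within the scatter) lies within the scatter, so the two compounds cannot be ordered. Compound 4 `CC[C@H](C)[C@H](NC(=O)c1cccc(Cn2ccnc2)c1)C(=O)NNS(=O)(=O)c1c(C)cc(C)cc1C` differs from compound 1 at the sulfonyl end: 2,4,6-trimethylphenyl in place of phenyl on a sulfonyl sulfur. Among the measured compounds shown here, no measured step touches that ring; the single measured step concerns the linker between the carbonyl and the sulfonyl and shows no real movement. With both measured numbers near the bottom of the scale, the expectation for compound 4 is a step of a number 1 percentage points higher from compound 1 to compound 4 (within the scatter), no larger than the scatter. Compound 4 is estimated at 7%, within -5% to 20%.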

Compound 4, a percentage reported as inhibition, at one concentration (the size of the read-out at that concentration, not a potency): 10%
The estimate for compound 4 lay 3 percentage points below the measured number; low and high end bracket the measured number.
By their numbers in this assay, from the lowest: compounds 2, 1 and 4 (each within the scatter of the next).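

In this assay, putting 2,4,6-trimethylphenyl in place of phenyl on the sulfonyl sulfur gives a number 4 percentage points higher from compound 1 to compound 4 (within the scatter). The earlier step changed only the linker, whereas this one shows that the ring on the sulfur can carry three added methyl groups without a change that stands clear of the scatter. Nothing measured here offers an explanation for this result. Still open, as far as these compounds go, is whether a carboxylic acid or an amine on that ring, or a pyridine ring in place of phenyl, would move the read-out beyond the scatter.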